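Ethyl in place of hydrogen on the phenol oxygen

This account rests on a few compounds, and the source may have more. Where it says the series, first, only, none or still open, it means among the compounds named here.

Compound 1 `COC(=O)C1=C(C)NC(=O)N(C(=O)NCCCN2CCN(c3ccccc3O)CC2)C1c1ccc(F)c(F)c1` is the stronger of the two compounds measured in an assay on liver for binding affinity to Alpha-1B adrenergic receptor (Homo sapiens), using microsomes; on this read-out lower numbers stand for stronger inhibition and higher numbers for weaker inhibition: compound 1 gives 16 nM, while compound 2 `CCC1=C(C(N)=O)C(c2ccc(F)cc2F)N(C(=O)NCCCN2CCN(c3ccccc3C(N)=O)CC2)C(=O)N1` gives 720 nM, a gap beyond the scatter. Compound 3 `CCOc1ccccc1N1CCN(CCCNC(=O)N2C(=O)NC(C)=C(C(=O)OC)C2c2ccc(F)c(F)c2)CC1` is reached from compound 1 by one change, (ethyl in place of hydrogen on an oxygen on an aromatic ring), that is, hydroxy to ethoxy on the 2-hydroxyphenyl group. Among the compounds with values here, no measured pair shows this change. The step is expected to be small, most likely a slight loss within or just beyond the scatter, a 1.6-fold higher number from compound 1 to compound 3 (0.19 log units; within the scatter). Compound 3 is therefore estimated at 25 nM, within a range from 6 nM to 100 nM.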

Compound 3, inhibition constant: 8.8 nM
For compound 3 the middle estimate is 2.8-fold (0.45 log units) above the measured one; the measured number falls inside the stated range.
By their numbers in this assay, from the lowest: compounds 3 and 1 (each within the scatter of the next); then compound 2.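

In this assay, the change from hydroxy to ethoxy on the 2-hydroxyphenyl group gives a 1.8-fold lower number from compound 1 to compound 3 (0.26 log units; within the scatter) and so leaves the affinity unchanged within the scatter. This shows that, on this core, the hydrogen on this oxygen can be replaced by ethyl without a measurable loss. Nothing available explains this tolerance. The compounds shown leave open whether a longer chain or a cyclopropylmethyl group on this oxygen would be tolerated equally. They also leave open what an amine in place of the oxygen would give.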